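Hydroxy in place of hydrogen on compound 3

This account rests on a few compounds, and the source may have more. Where it says the series, first, only, none or still open, it means among the compounds named here.

Compound 1 `CC(=O)S[C@]12CC[C@H](O)[C@H]1C(=O)NC2=O`: 833000 nM
Compound 2 `O=C(S[C@]12CC[C@H](O)[C@H]1C(=O)NC2=O)c1ccccc1`: 65200 nM
Compound 3 `O=C(S[C@]12CCC[C@H]1C(=O)NC2=O)c1ccc(F)cc1`: 390000 nM

All three were read in a functional assay on RAW264.7 cells (Mus musculus) for inhibition, read by Griess assay, with a stated time of 24 h; a higher number here means a weaker inhibitor, a lower number a stronger inhibitor. Compound 3 holds the middle place: its number is lower than that of compound 1 and higher than that of compound 2, with compound 3 at 390000 nM, compound 1 at 833000 nM and compound 2 at 65200 nM.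

Compound 4 `O=C(S[C@]12CC[C@H](O)[C@H]1C(=O)NC2=O)c1ccc(F)cc1` is compound 3 with a single change, hydroxy in place of hydrogen on a saturated ring carbon. For the measured compounds named here, the one measured step, a 13-fold lower number from compound 1 to compound 2 (1.11 log units; beyond the scatter), is large, but it concerns the group on the carbonyl carbon, so no measured step tests this hydroxy directly. The nearest evidence is compound 2, which bears the hydroxy and stands at 65200 nM, although it also lacks the fluorine of compound 3, so its gap to compound 3 is not a clean measure. A clear move toward a lower number is therefore expected, and the estimated step is a 5.2-fold lower number from compound 3 to compound 4 (0.72 log units; beyond the scatter). Compound 4 is expected at 75000 nM, with an estimated range of 25000 nM to 220000 nM.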

Compound 4, half-maximal inhibitory concentration: 318000 nM
Beside the measured number, compound 4's estimate is 4.2-fold (0.63 log units) below it; measured number outside the range, above it.
By their numbers in this assay, from the lowest: compound 2; then compounds 4 and 3 (each within the scatter of the next); then compound 1.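

In this assay the pair that tests this change directly gives a 1.2-fold lower number from compound 3 to compound 4 (0.09 log units; within the scatter) and so shows no difference that can be told from the scatter for hydroxy in place of hydrogen on this saturated ring carbon. With the hydroxy held in place, the differences lie in the group on the carbonyl carbon: fluoro in place of hydrogen on an aromatic carbon gives a 4.9-fold higher number from compound 2 to compound 4 (0.69 log units; beyond the scatter) here, and 4-fluorophenyl in place of methyl gives a 2.6-fold lower number from compound 1 to compound 4 (0.42 log units; beyond the scatter) here. No measurement is at hand that explains these numbers.

As far as these compounds go, whether the hydroxy would matter on a phenyl without the fluoro remains open, since only the 4-fluorophenyl pair tests it. Also open, from the compounds shown here alone, is how a methoxy or an amine on this ring carbon would read.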